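Swapping dipropylamino for pyrrolidin-1-yl in compound 3

The source may report more compounds than this note shows. Statements on the series, on what has been measured and on what is new or still open speak of the compounds shown alone.

Going by the values given here, in an ADME assay on HepG2 cells (Homo sapiens) for cytotoxicity (on this read-out higher numbers stand for lower toxicity in this test and lower numbers for higher toxicity in this test), compound 3 (`CCCN(CC#Cc1cc2c(Nc3ccc(OCc4cccc(F)c4)c(Cl)c3)ncnc2s1)CCC`) gives 17 uM, the only exact number among the measured compounds. Compound 1 (`Fc1cccc(COc2ccc(Nc3ncnc4cc(C#CCN5CCNCC5)sc34)cc2Cl)c1`) gives > 29 uM, which is a limit of the assay. Compound 2 (`Fc1cccc(COc2ccc(Nc3ncnc4cc(C#CC5CCCC5)sc34)cc2Cl)c1`) gives > 31 uM, which is also a limit.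

Compound 4 (`Fc1cccc(COc2ccc(Nc3ncnc4sc(C#CCN5CCCC5)cc34)cc2Cl)c1`) keeps the core of compound 3 but carries pyrrolidin-1-yl in place of dipropylamino on a saturated chain carbon bound to a triple-bonded carbon.

Among the compounds with values here, only one measured step is available, a step that the two limits leave unreadable from compound 1 to compound 2. It gives no size to carry over, and it involves different groups on a differently arranged core. Within the data shown here, no measured step therefore shows what this swap does in this assay. The expectation stays anchored on compound 3 at 17 uM, with no clear direction and no change beyond the usual scatter. The expected step is a 1.2-fold higher number from compound 3 to compound 4 (0.07 log units; within the scatter). For compound 4 the estimated value is 20 uM, with an expected range from 9 uM to 40 uM.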

Compound 4, half-maximal toxic concentration: > 30 uM
Compound 4 was reported as a limit (the forecaster's own chance of this, stated with the estimate: 25%); middle value at least 1.5-fold (0.17 log units) away from the limit.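

In this assay, going by these compounds alone, this is the first step at this position that can be read at all, and it has a direction: an at least 1.7-fold higher number from compound 3 to compound 4 (0.24 log units; that floor lies within the scatter). Only a floor is known for the swap of open-chain dipropylamino for the pyrrolidin-1-yl ring, and since that floor lies within the usual scatter, the step does not establish a real gain, though it does show that the ring brings no lower number. Compound 4 is reported only as a limit, and the true size of the step stays unknown because of that limit: the limit of > 30 uM in this assay, at which 1 of the 4 values shown sits.

The compounds shown leave open whether this reading holds for other amines at this place on the same core, such as dimethylamino or morpholin-4-yl. They also leave open whether a longer chain carrying the pyrrolidin-1-yl ring would read the same way.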